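The source may report more compounds than this note shows. Statements on the series, on what has been measured and on what is new or still open speak of the compounds shown alone.

Series notes. Compound 1 `CCC(CC)(c1ccc(OCC(O)CO)c(C)c1)c1ccc(OCC(O)C(C)(C)C)c(OCC(O)C(C)(C)C)c1` and compound 2 `CCC(CC)(c1ccc(OCCCCCO)c(C)c1)c1ccc(OCC(O)C(C)(C)C)c(OCC(O)C(C)(C)C)c1` share a core and differ only on one side chain. In an assay on cells for binding affinity to vitamin D3 receptor (Homo sapiens), read by fluorescence, tested at 1 uM (on this read-out higher numbers stand for more inhibition at the one concentration tested (going by the name of the read-out) and lower numbers for less inhibition), compound 1 gives 78% and compound 2 gives 67%; the change from 1,2-dihydroxyethyl to 4-hydroxybutyl on a saturated chain carbon bound to an oxygen on an aromatic ring reads as a number 11 percentage points lower from compound 1 to compound 2 (beyond the scatter). On the numbers shown compound 2 stands lowest of the two, with compound 1 as its only neighbour.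

Compound 3 `CCC(CC)(c1ccc(OCC(=O)O)c(C)c1)c1ccc(OCC(O)C(C)(C)C)c(OCC(O)C(C)(C)C)c1` is not yet measured. Against compound 2 it shows (carboxy in place of 4-hydroxybutyl on a saturated chain carbon bound to an oxygen on an aromatic ring). For the measured compounds named here, the single step bearing on this position, a number 11 percentage points lower from compound 1 to compound 2 (beyond the scatter), was modest, and no measured pair shows a carboxy at this place, so direction is uncertain; a step of about a number 2 percentage points lower from compound 2 to compound 3 (within the scatter) in this assay is expected, within the scatter. For compound 3 the estimate in this assay is 65%, with a range from 45% to 85%.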

Compound 3, a percentage reported as inhibition, at one concentration (the size of the read-out at that concentration, not a potency): 10%
For compound 3 the middle estimate is 55 percentage points above the measured one, outside the stated range (below it).
By their numbers in this assay, from the lowest: compound 3; then compound 2; then compound 1.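

In this assay, for the compounds shown here, the place on a saturated chain carbon bound to an oxygen on an aromatic ring proves far more sensitive than the one earlier step suggested: a number 57 percentage points lower from compound 2 to compound 3 (beyond the scatter), and a number 68 percentage points lower from compound 1 to compound 3 (beyond the scatter). Both steps are large, whereas the exchange of 1,2-dihydroxyethyl for 4-hydroxybutyl was modest, so among these three compounds the two hydroxy-bearing chains stay close and the carboxy chain falls well away. Nothing available on these compounds speaks to the reason for this drop.

The carboxy group also brings a shorter side chain than 4-hydroxybutyl, so the compounds shown do not separate the end group from the chain length. A longer chain ending in a carboxylic acid, or an amide or amine at this place, would bear on that question.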